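The compounds below may be only part of what the source reports. "The series", "measured", "known", "first", "only" and "open" are said of these compounds alone.

In an assay on CHO cells for displacement of a labelled ligand from adenosine receptor A1 (Homo sapiens), tested at 10 uM (on this read-out lower numbers stand for less inhibition and higher numbers for more inhibition at the one concentration tested (going by the name of the read-out)), compound 1 `OC[C@@]1(O)CO[C@@H](n2cnc3c(NCc4cccc(Cl)c4)ncnc32)[C@@H]1O` gives 10%, and compound 2 `CNC(=O)OC[C@@]1(O)CO[C@@H](n2cnc3c(N)ncnc32)[C@@H]1O` gives 12%. Compound 2 holds the higher of the two numbers, but compound 1 sits only a shade lower, a gap within the scatter, so no order can be read from them. Compound 3 `Nc1ncnc2c1ncn2[C@@H]1OC[C@](O)(CO)[C@H]1O` differs from compound 2 by hydrogen in place of methylcarbamoyl on an oxygen on a saturated carbon. Among the measured compounds shown here, no measured pair shows the effect of this change, so the step is expected to stay within the scatter, with a small move downward at most: a number 3 percentage points lower from compound 2 to compound 3 (within the scatter) is estimated. Compound 3 is therefore expected to give about 9%, between 0% and 24%.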

Compound 3, a percentage reported as inhibition, at one concentration (the size of the read-out at that concentration, not a potency): 6%
Beside the measured number, compound 3's estimate is 3 percentage points above it; measured number inside the range.
By their numbers in this assay, from the lowest: compounds 3, 1 and 2 (each within the scatter of the next).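

With hydrogen in place of methylcarbamoyl on an oxygen on a saturated carbon, this assay shows a number 6 percentage points lower from compound 2 to compound 3 (within the scatter) and, with hydrogen in place of 3-chlorobenzyl on a nitrogen on an aromatic ring, a number 4 percentage points lower from compound 1 to compound 3 (within the scatter) in the same read-out. At this single concentration, neither group therefore stands apart from hydrogen at its position. No measurement at hand bears on this result.

On these data alone, whether a longer chain on that oxygen or an amine on the benzyl group would move the number beyond the scatter remains open. So does the effect of carrying 3-chlorobenzyl and methylcarbamoyl together.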